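The source may hold more compounds than are shown below. What is called first, only, known or untested is meant among the compounds shown, and "the series" means these compounds.

Of the compounds shown here, three sharing one core have been measured in a functional assay on HCT-116 cells (Homo sapiens) for antiproliferative activity, read by MTT assay, with a stated time of 72 h; a higher number here means a weaker inhibitor, a lower number a stronger inhibitor. Compound 1 `COc1cccc(C(=O)N(C)c2ccc3[nH]c(-c4n[nH]c5ccccc45)cc3n2)c1` gives 14200 nM, compound 2 `CN(C(=O)c1ccco1)c1ccc2[nH]c(-c3n[nH]c4ccccc34)cc2n1` gives 30000 nM, and compound 3 `Cc1ccc(S(=O)(=O)N(C)c2ccc3[nH]c(-c4n[nH]c5ccccc45)cc3n2)cc1` gives 13300 nM. Within the data shown here, compound 3 holds the lowest number of the three, but its gap to compound 1 is within the scatter, as a 1.1-fold lower number from compound 1 to compound 3 (0.03 log units; within the scatter) shows; only the step of a 2.3-fold lower number from compound 2 to compound 3 (0.35 log units; beyond the scatter) goes beyond it, and a 2.1-fold higher number from compound 1 to compound 2 (0.32 log units; beyond the scatter) is of the same modest size in the other direction.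

Compound 4 `COc1ccc(S(=O)(=O)N(C)c2ccc3[nH]c(-c4n[nH]c5ccccc45)cc3n2)cc1` differs from compound 3 by methoxy in place of methyl on an aromatic carbon, that is, 4-methylphenyl becomes 4-methoxyphenyl, para to a large group. Among the measured compounds shown here, no measured step touches a substituent on this ring: the steps from compound 1 and compound 2 to compound 3 exchange the whole carbonyl or sulfonyl unit, and the one methoxy change in the set, on compound 1, sits on a different aryl group. No step beyond the scatter is therefore expected in this assay for compound 4, which is estimated at 13000 nM (range 6000 nM to 30000 nM), a step of a 1.0-fold lower number from compound 3 to compound 4 (0.01 log units; within the scatter) from compound 3.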

Compound 4, half-maximal inhibitory concentration: 22400 nM
For compound 4 the middle estimate is 1.7-fold (0.24 log units) below the measured one; the range from low to high includes it.
By their numbers in this assay, from the lowest: compounds 3, 1, 4 and 2 (each within the scatter of the next, the first and the last beyond it).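

Among these compounds, the first substituent change on this aryl ring, 4-methylphenyl to 4-methoxyphenyl, gives no readable shift in this assay: a 1.7-fold higher number from compound 3 to compound 4 (0.23 log units; within the scatter). At this place, para to a large group, methoxy in place of methyl adds an oxygen and a hydrogen-bond acceptor, and the step from that exchange stays inside the scatter, so the sulfonyl series shows no sensitivity to this particular change. No independent measurement is available to explain the result.

Going by these compounds, whether a group of another kind at this place, such as an amine, a carboxylic acid or a longer chain like butoxy, would give a step beyond the scatter remains open. Also open, on these data alone, is whether the same exchange of methyl and methoxy would read the same way with a carbonyl in place of the sulfonyl.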